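Expected cytotoxicity of compound 4 against HepG2 cells

The compounds below may be only part of what the source reports. "The series", "measured", "known", "first", "only" and "open" are said of these compounds alone.

Measured compounds:
compound 1 `CCOC(=O)CCCCCOc1cccc(CN(C(=O)c2ccc(-c3ccncc3)cc2)C(C)C)c1`: > 26000 nM
compound 2 `CCOC(=O)CCCCCOc1cccc(CN(C(=O)c2ccc(-c3cccc(-c4ccccc4)c3)cc2)C(C)C)c1`: > 26000 nM
compound 3 `CCOC(=O)CCCCCOc1cccc(CN(C(=O)c2ccc(-c3cccc(OC)c3)cc2)C(C)C)c1`: > 21000 nM

Compounds 1, 2 and 3 share one core and differ only in the group attached to an aromatic carbon. In an ADME assay on HepG2 cells (Homo sapiens) for cytotoxicity, read by CellTiter-Glo and resazurin assay, with a stated time of 72 h (a higher number here means that more compound is needed for the effect, a lower number that less compound is needed), compound 1 gives > 26000 nM, which is a limit of the assay and not a number. Compound 2 gives > 26000 nM in this assay, again a limit. Compound 3 gives > 21000 nM, also a limit rather than a measured value. Compound 3 thus stands at a limit, and so do the two other values; the steps a step that the two limits leave unreadable from compound 1 to compound 3 and a step that the two limits leave unreadable from compound 2 to compound 3 are of unreadable size, as is a step that the two limits leave unreadable from compound 1 to compound 2. The evidence consists only of the limit of > 21000 nM in this assay, at which 1 of the 3 values shown sits, and (the limit of > 26000 nM in this assay, at which 2 of the 3 values shown sit).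

Compound 4 `CCOC(=O)CCCCCOc1cccc(CN(C(=O)c2ccc(-c3ccc4[nH]ccc4c3)cc2)C(C)C)c1` differs from compound 3 in that (1H-indol-5-yl in place of 3-methoxyphenyl on an aromatic carbon). The measured steps that bear on this change are all unreadable, so no direction beyond the scatter can be drawn from them. Compound 4 is therefore expected to give an estimated 30000 nM in this assay, within 15000 nM to 60000 nM, most likely again reported only as a limit. The expected step that the limit leaves unreadable from compound 3 to compound 4 is estimated to lie within the scatter.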

Compound 4, half-maximal effective concentration: > 26000 nM
Compound 4 ended at the assay's limit; the forecaster's own chance of this, stated with the estimate: 85%; the middle value does not contradict the limit.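

All four values are limits of the assay, and the steps from compound 1, compound 2 and compound 3 to compound 4 cannot be read. The compounds shown leave open whether these four groups on the aromatic carbon differ at all in this assay.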